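Swapping an Acid for an Amide: What Compound 4 Should Give

This account rests on a few compounds, and the source may have more. Where it says the series, first, only, none or still open, it means among the compounds named here.

Compound 1 `Cn1ncc2cc(-c3cnccc3/C=C/C(=O)O)ccc21` and compound 2 `Cn1ccc2cc(-c3cnccc3/C=C/C(=O)O)ccc21` carry the same acid-bearing side chain on two closely related cores; the difference between the two cores is not broken down here. In an assay on a protein complex for inhibition of CDK8/Cyclin C (Homo sapiens), with a stated time of 1 h, tested at 10 uM (a lower number here means less inhibition, a higher number more inhibition at the concentration tested (going by the name of the read-out)), compound 1 gives 102%, and compound 2 gives 102%. Compound 3 `CNC(=O)/C=C/c1ccncc1-c1ccc2c(ccn2C)c1` differs from compound 2 by methylamino in place of hydroxy on a carbonyl carbon, and in this assay compound 3 gives 99%, so that a number 3 percentage points lower from compound 2 to compound 3 (within the scatter). Compound 4 `CNC(=O)/C=C/c1ccncc1-c1ccc2c(cnn2C)c1` has not yet been measured; it differs from compound 1 by methylamino in place of hydroxy on a carbonyl carbon, the same change, made at the same kind of place. Going by the values given here, the only guide is the step of a number 3 percentage points lower from compound 2 to compound 3 (within the scatter), which lies within the scatter. For compound 4 a step of a number 3 percentage points lower from compound 1 to compound 4 (within the scatter) is expected. Compound 4 is therefore expected to give about 99% in this assay, most likely between 92% and 105%.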

Compound 4, a percentage reported as inhibition, at one concentration (the size of the read-out at that concentration, not a potency): 98%
The estimate for compound 4 lay 1 percentage points above the measured number; the range from low to high includes it.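

On the core of compound 1, methylamino in place of hydroxy on a carbonyl carbon gives a number 4 percentage points lower from compound 1 to compound 4 (within the scatter) in this assay. Set beside the earlier step, the change carries from one core to the other with no visible difference: the same change on two cores in this assay, a number 3 percentage points lower (within the scatter) from compound 2 to compound 3 and a number 4 percentage points lower (within the scatter) from compound 1 to compound 4, 1 percentage points apart, within the scatter of two such steps. Going by these compounds alone, this shows only that the swap leaves the read-out unmoved on these two cores at one tested concentration; the read-out is not a potency, and a real difference in potency between the acid and the amide could stay hidden.

The compounds shown leave open what an ethylamino or dimethylamino group, or a methyl ester, would give in place of the methylamino group. They also leave open whether the same change behaves alike on any other core.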